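Epimer at a ring carbon in a polar glycoside series

This account rests on a few compounds, and the source may have more. Where it says the series, first, only, none or still open, it means among the compounds named here.

Two members of the series carry a measurement in a physicochemical assay for lipophilicity, using the shake flask method; a higher number here means a more lipophilic compound, a lower number a more polar compound. Compound 1, `CC(=O)N[C@H]1[C@H](OCCN(C)C(=O)Cn2ccnc2[N+](=O)[O-])O[C@H](CO)[C@H](O)[C@@H]1O`, is the acetamido-bearing analogue; in this assay compound 1 gives < 0.01, which is a limit of the assay and not a number. Compound 2, `CN(CCO[C@@H]1O[C@H](CO)[C@@H](O)[C@H](O)[C@H]1O)C(=O)Cn1ccnc1[N+](=O)[O-]`, is the parent of the present step; in this assay compound 2 gives < 0.01, again a limit rather than a number. Among the compounds with values here, what the data show is summed up by the limit of < 0.01 in this assay, at which 2 of the 2 values shown sit, so compound 2 stands at the floor of the measurable range, with no measured step in this assay from which to read the size of a configurational change.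

The unmeasured compound 3, `CN(CCO[C@@H]1O[C@H](CO)[C@H](O)[C@H](O)[C@H]1O)C(=O)Cn1ccnc1[N+](=O)[O-]`, differs from compound 2 as follows: the two compounds have the same atoms and bonds and differ only in configuration as drawn: 1 of 5 stereo elements differ; a stereocentre at a saturated ring carbon is drawn S in compound 2 and R in compound 3. Within the data shown here, no step between measured compounds exists here; for an inversion of a single ring stereocentre with the same atoms and bonds, no change beyond the scatter is expected, and the step from compound 2 to compound 3 is estimated as a step that the limit leaves unreadable from compound 2 to compound 3. For compound 3 the expected value in this assay is -0.2, with a range from -0.8 to 0.3, most likely reported again as a limit.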

Compound 3, partition coefficient: < 0.01
Compound 3: a limit, no number (the forecaster's own chance of this, stated with the estimate: 85%); the middle value lies beyond the limit too.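

Compound 3 gives < 0.01 in this assay and this is a limit of the assay, not a number. The steps from compound 1 and from compound 2 to compound 3 therefore cannot be read. Still open, on these data alone, is what size either change, the inverted ring stereocentre or hydroxy in place of acetamido, would have on a compound that gives a measurable number.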